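From 3-hydroxy-3-methylazetidin-1-yl to dimethylamino on the carbonyl carbon

The source may hold more compounds than are shown below. What is called first, only, known or untested is meant among the compounds shown, and "the series" means these compounds.

In an ADME assay on MDCKII-LE cells (Canis lupus familiaris) for permeability (a lower number here means that the compound crosses the layer more slowly, a higher number that the compound crosses the layer faster), compound 1 (`Cc1cc2c(Oc3cnc(C(=O)N4CC(C)C4)cn3)cc(C(=O)Nc3cnccn3)cc2o1`) gives 14.9 10^-6 cm/s and compound 2 (`COC1CN(C(=O)c2cnc(Oc3cc(C(=O)Nc4cnccn4)cc4oc(C)cc34)cn2)C1`) gives 21.8 10^-6 cm/s on the shared core. Compound 3 (`Cc1cc2c(Oc3cnc(C(=O)N4CC(C)(O)C4)cn3)cc(C(=O)Nc3cnccn3)cc2o1`) gives 9 10^-6 cm/s and so stands within the scatter of compound 1 (a 1.7-fold lower number from compound 1 to compound 3 (0.22 log units; within the scatter)) but beyond the scatter under compound 2 (a 2.4-fold lower number from compound 2 to compound 3 (0.38 log units; beyond the scatter)).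

Compound 4 (`Cc1cc2c(Oc3cnc(C(=O)N(C)C)cn3)cc(C(=O)Nc3cnccn3)cc2o1`) carries dimethylamino in place of 3-hydroxy-3-methylazetidin-1-yl on a carbonyl carbon. Among the compounds with values here, no measured pair goes from a ring to dimethylamino on this carbonyl, so that part of the change has no direct guide. The closest evidence is the hydroxy step (a 1.7-fold lower number from compound 1 to compound 3 (0.22 log units; within the scatter)), which, read backwards, points to a number nearer compound 1 than compound 3 once the hydroxy is gone. The methoxy step (a 1.5-fold higher number from compound 1 to compound 2 (0.17 log units; within the scatter)) stays within the scatter, and compound 2 offers a second reference without a hydroxy. A small rise is therefore expected, of about the size of the hydroxy step, and the estimated step (a 1.8-fold higher number from compound 3 to compound 4 (0.25 log units; within the scatter)) may not clear the scatter. In this assay compound 4 is expected at 16 10^-6 cm/s (estimated range 9 10^-6 cm/s to 28 10^-6 cm/s).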

Compound 4, apparent permeability: 30 10^-6 cm/s
The estimate for compound 4 lay 1.9-fold (0.27 log units) below the measured number; the whole stated range lies below it.
By their numbers in this assay, from the lowest: compounds 3, 1, 2 and 4 (each within the scatter of the next, the first and the last beyond it).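

In this assay, an open-chain dimethylamino on this carbonyl carbon stands beyond the scatter of the hydroxylated ring (a 3.3-fold higher number from compound 3 to compound 4 (0.52 log units; beyond the scatter)) but within the scatter of both ring groups without hydroxy (a 1.4-fold higher number from compound 2 to compound 4 (0.14 log units; within the scatter); a 2.0-fold higher number from compound 1 to compound 4 (0.30 log units; within the scatter)), so among these four compounds the azetidine ring is not required to reach the range of compound 1 and compound 2. Compound 3, the only one of the four with a hydroxy group, now lies beyond the scatter of two compounds, compound 2 and compound 4, although compound 1 goes against a clean split, lying within the scatter of both compound 3 and compound 4. The data at hand give no reason for these differences.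

The step from compound 3 to compound 4 removes the ring and the hydroxy together, so the share of each cannot be separated. From the compounds shown here alone, whether a hydroxy group on an open chain, as in a hydroxyethylamino group, would sit with compound 3 or with compound 4 remains open, as does the effect of a longer chain such as diethylamino at this carbonyl carbon.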